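This account rests on a few compounds, and the source may have more. Where it says the series, first, only, none or still open, it means among the compounds named here.

Measured compounds:
compound 1, `c1ccc(-c2cn[nH]c2)c(NCC2=NCCN2)c1`, 20 nM
compound 2, `Cn1cccc1-c1ccccc1NCC1=NCCN1`, 251 nM

Compound 2 stands highest of the two numbers in an in vitro functional assay on cells (Fibroblast) for agonist activity at Alpha-1D adrenergic receptor (Homo sapiens); on this read-out lower numbers stand for an effect already at smaller amounts and higher numbers for an effect only at larger amounts of compound; its nearest neighbour is compound 1, reached by a 13-fold higher number from compound 1 to compound 2 (1.10 log units; beyond the scatter), a change of the whole aromatic substituent rather than of its alkyl group.

Compound 3, `CCn1cccc1-c1ccccc1NCC1=NCCN1`, differs from compound 2 by methyl in place of hydrogen on a saturated chain carbon bound to an aromatic nitrogen. No measured step bears directly on this change: the only step shown swaps one ring for another and says nothing about lengthening the alkyl group on the aromatic nitrogen. With no guidance from the measured pair, the expected step in this assay is small, a 1.2-fold higher number from compound 2 to compound 3 (0.08 log units; within the scatter), within the usual scatter and with no clear direction.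

Compound 3 is therefore estimated at 300 nM in this assay, within a range from 120 nM to 800 nM.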

Compound 3, half-maximal effective concentration: < 100000 nM
Compound 3: no number, only a limit; the forecaster's own chance of this, stated with the estimate: 3%; the middle value lies beyond the limit too.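

In this assay compound 3 gives only a limit, < 100000 nM, not a number. For the compounds shown here, no step from compound 2 to compound 3 can be read from it. The compounds shown leave open whether going from methyl to ethyl changes the read-out at all, and in which direction.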